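Cyclobutyl to Cyclopentyl: Does the Receptor Notice?

A few compounds are considered here, and "the series" means these few. Any claim that something is new, unique, unknown or untested is made for them only; others in the source may bear on it.

Of the compounds shown here, two have been tested in an assay on membranes from HeLa cells for displacement of a labelled ligand from adenosine receptor A3 (Homo sapiens), read by scintillation counting, with a stated time of 180 min, tested at 1 uM; on this read-out higher numbers stand for more inhibition at the one concentration tested (going by the name of the read-out) and lower numbers for less inhibition. Compound 1 `CC1=C(C(=O)OC2CCCC2)C(c2ccoc2)NC(=O)N1` gives 1% in this assay. Compound 2 `CC1=C(C(=O)OC2CCC2)C(c2cccs2)NC(=O)N1` gives 2% in this assay, a number that sits alongside that of compound 1, the gap between them lying within the usual scatter, so the two numbers can only be called level.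

The next compound, compound 3 `CC1=C(C(=O)OC2CCCC2)C(c2cccs2)NC(=O)N1`, differs from compound 2 in one place: cyclopentyl in place of cyclobutyl on an oxygen next to a carbonyl group. The same swap of ring size appears between compound 1 and compound 2, though those two also differ elsewhere, so no clean reading of this change exists yet.

With both measured numbers near the floor of the read-out, the expected no change at the digits printed from compound 2 to compound 3 (within the scatter) is none beyond the scatter. Compound 3 is therefore expected to give about 2% in this assay, within a range from -6% to 12%.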

Compound 3, a percentage reported as inhibition, at one concentration (the size of the read-out at that concentration, not a potency): 1%
Compound 3: middle estimate off by 1 percentage points, on the high side; low and high end bracket the measured number.
By their numbers in this assay, from the lowest: compounds 1, 3 and 2 (each within the scatter of the next).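

Cyclopentyl in place of cyclobutyl on an oxygen next to a carbonyl group now stands alone as a single change in this assay and gives a number 1 percentage points lower from compound 2 to compound 3 (within the scatter) with the rest of the structure held the same. The group on the saturated ring carbon can now be read alone as well, since thiophen-2-yl in place of furan-3-yl gives no change at the digits printed from compound 1 to compound 3 (within the scatter) with the cyclopentyl kept in place. Neither of the two changes separates the compounds on this read-out, and nothing at hand bears on the reason for that.

All three numbers lie low, so the compounds shown leave open whether either place can move the read-out at all. An ethyl or a longer chain on that oxygen, or a phenyl on the saturated ring carbon, remains an open case.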